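The source may hold more compounds than are shown below. What is called first, only, known or untested is meant among the compounds shown, and "the series" means these compounds.

Compound 1, `COc1cc(CCc2cccc(F)c2)cc(OC)c1O`, and compound 2, `COc1cc(CCc2ccccc2F)cc(OC)c1O`, share the same core and differ only in where the fluoro sits on the second ring. In a functional assay on MKN-45 cells (Homo sapiens) for antiproliferative activity, read by MTT assay, with a stated time of 72 h (a higher number here means a weaker inhibitor, a lower number a stronger inhibitor), compound 1 gives 2970 nM. Compound 2, by contrast, reaches only a limit of the assay, > 25000 nM. Compound 2 therefore stands at the limit of > 25000 nM in this assay, at which 1 of the 2 values shown sits, with no number of its own. Compound 3, `COc1ccccc1CCc1cc(OC)c(O)c(OC)c1`, is not yet measured; it is derived from compound 2 by the change (methoxy in place of fluoro on an aromatic carbon), a methoxy in place of fluoro on an aromatic carbon. Since compound 2 gives only a limit, the size of the step cannot be fixed from its side, and the expected step from compound 2 to compound 3 is an at least 1.6-fold lower number from compound 2 to compound 3 (0.22 log units; that floor lies within the scatter), with a real chance that compound 3 again ends at the limit. The estimate for compound 3 in this assay is 15000 nM, with a range from 4000 nM to 40000 nM.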

Compound 3, half-maximal inhibitory concentration: 2480 nM
Estimate against measurement, compound 3: 6.0-fold (0.78 log units) above, outside the stated range (below it).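

In this assay, replacing the fluoro of compound 2 with a methoxy on an aromatic carbon, ortho to a large group, gives an at least 10-fold lower number from compound 2 to compound 3 (1.00 log units; beyond the scatter). Before this result, the only compound with a substituent at this place had ended at the assay limit; compound 3 shows that a compound substituted here can return a measured value, so the group on this carbon decides the outcome. Compound 2 has only a limit and no number of its own, so the step is a floor and its true size remains unknown: the limit of > 25000 nM in this assay, at which 1 of the 3 values shown sits.

As far as these compounds go, it remains open whether this gain is particular to methoxy or would also appear with a hydroxyl, an amine or a longer chain such as ethoxy on the same carbon. The compounds shown also cannot tell whether methoxy would behave the same way elsewhere on that ring.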